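A few compounds are considered here, and "the series" means these few. Any claim that something is new, unique, unknown or untested is made for them only; others in the source may bear on it.

Three compounds share the same core, a saturated carbon that carries two aromatic rings, and differ only in the branched chain attached to that carbon. In a functional assay on HeLa cells (Homo sapiens) for cytotoxicity, read by WST assay, with a stated time of 48 h (a higher number here means a weaker inhibitor, a lower number a stronger inhibitor), compound 1 `CCCCC[C@H](C(C)C)C(c1ccc(O)c(OC)c1)c1ccc(O)c(OC)c1` gives 9200 nM. Compound 2 `COc1cc(C(c2ccc(O)c(OC)c2)[C@@H](C)[C@H](C)CF)ccc1O` gives 37000 nM, and compound 3 `COC[C@H](C)[C@@H](C)C(c1ccc(O)c(OC)c1)c1ccc(O)c(OC)c1` gives 77000 nM, the highest number of the three, so compound 3 is the weakest inhibitor in this small set. Each change of the chain so far has been modest: a 4.0-fold higher number from compound 1 to compound 2 (0.60 log units; beyond the scatter), an 8.4-fold higher number from compound 1 to compound 3 (0.92 log units; beyond the scatter) and a 2.1-fold higher number from compound 2 to compound 3 (0.32 log units; beyond the scatter).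

Compound 4 `COc1cc(C(c2ccc(O)c(OC)c2)[C@H](C)C(C)C)ccc1O` follows from compound 3 by one change: hydrogen in place of methoxy on a saturated chain carbon, four bonds along the chain from two aromatic carbons. The two steps that end at compound 3 both bear on this, since each replaced a chain without a methoxy by the chain that has it, and the number rose each time. Removing the methoxy is therefore expected to lower the number, by a step of about a 2.2-fold lower number from compound 3 to compound 4 (0.34 log units; beyond the scatter), in the direction of compound 2. Compound 4 is thus estimated to give 35000 nM in this assay, with a likely range from 12000 nM to 90000 nM.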

Compound 4, half-maximal inhibitory concentration: 16000 nM
For compound 4 the middle estimate is 2.2-fold (0.34 log units) above the measured one; the range from low to high includes it.
By their numbers in this assay, from the lowest: compounds 1 and 4 (each within the scatter of the next); then compound 2; then compound 3.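

Hydrogen in place of methoxy at this chain carbon gives a 4.8-fold lower number from compound 3 to compound 4 (0.68 log units; beyond the scatter) in this assay, so the plain 1,2-dimethylpropyl chain gives a lower number than the chain that carries methoxy. The same chain also compares favourably with the one that carries fluorine, with a 2.3-fold lower number from compound 2 to compound 4 (0.36 log units; beyond the scatter), so both groups shown on this carbon give a higher number than hydrogen does. Hydrogen in place of butyl gives a 1.7-fold higher number from compound 1 to compound 4 (0.24 log units; within the scatter), which means the shorter chain of compound 4 and the 1-isopropylhexyl chain of compound 1 cannot be told apart here.

No measurement shown accounts for these differences. On these data alone, it also remains open whether an amine, a hydroxyl or a carboxylic acid on this same chain carbon would likewise give a higher number than hydrogen.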